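This account rests on a few compounds, and the source may have more. Where it says the series, first, only, none or still open, it means among the compounds named here.

In an ADME assay on Caco-2 cells (Homo sapiens) for permeability, read by LC-MS, in the apical to basolateral direction, with a stated time of 60 min, at pH 6.5 (on this read-out lower numbers stand for lower permeability and higher numbers for higher permeability), compound 1 `O=C(NCc1cc(Cl)ccc1-n1cnnn1)[C@@H]1C[C@@H]2C[C@@H]2N1C(=O)[C@H](O)CC1CC1` gives 3.6 10^-6 cm/s, compound 3 `O=C(NCc1cc(Cl)ccc1-n1cnnn1)[C@@H]1[C@@H]2C[C@@H]2CN1C(=O)[C@H](O)Cc1ccccn1` gives 0.62 10^-6 cm/s, and compound 2 `Cc1cccc([C@@H](O)C(=O)N2N=CC[C@H]2C(=O)NCc2cc(Cl)ccc2-n2cnnn2)c1` gives 9.7 10^-6 cm/s, the highest of the three numbers and beyond the scatter from both others. Compound 4 `O=C(NCc1cc(Cl)ccc1-n1cnnn1)[C@@H]1CC=NN1C(=O)[C@H](O)Cc1ccccc1` holds the same atoms as compound 2, joined differently: benzyl in place of 3-methylphenyl on a saturated chain carbon bound to a carbonyl carbon and an oxygen on a saturated carbon. Among the measured compounds shown here, no step between measured compounds isolates this change. Compound 2, at 9.7 10^-6 cm/s, already stands at the top of the set, so a small fall is expected in this assay, not beyond the scatter. The estimated step is a 1.8-fold lower number from compound 2 to compound 4 (0.25 log units; within the scatter). Compound 4 is expected to give about 5.5 10^-6 cm/s, with an estimated range from 1.8 10^-6 cm/s to 14 10^-6 cm/s.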

Compound 4, apparent permeability: 11 10^-6 cm/s
Estimate against measurement, compound 4: 2.0-fold (0.30 log units) below; low and high end bracket the measured number.
By their numbers in this assay, from the lowest: compound 3; then compound 1; then compounds 2 and 4 (each within the scatter of the next).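

In this assay the change to benzyl in place of 3-methylphenyl on a saturated chain carbon bound to a carbonyl carbon and an oxygen on a saturated carbon gives a 1.1-fold higher number from compound 2 to compound 4 (0.05 log units; within the scatter) and so leaves the read-out unchanged within the scatter. Among the compounds shown here, this is the first step read at this position, and it shows that the two groups, with the same heavy atoms joined differently, cannot be told apart here. No measured evidence bears on this result. As far as these compounds go, whether a longer chain, an amine or a carboxylic acid in place of benzyl at this position would move the number stays open.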